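Adding chloro to the core of compound 1

This account rests on a few compounds, and the source may have more. Where it says the series, first, only, none or still open, it means among the compounds named here.

Measured in an ADME assay on 184B5 cells (Homo sapiens) for antiproliferative activity, read by sulforhodamine B assay, with a stated time of 72 h; on this read-out higher numbers stand for weaker inhibition and lower numbers for stronger inhibition:
- Compound 1 `Fc1ccc(/C=C\c2cc3ccccc3nc2Cl)cc1`: 35700 nM
- Compound 2 `Fc1ccc(/C=C/c2cc3ccccc3nc2Cl)cc1`: 38500 nM
- Compound 3 `FC(F)(F)c1ccc(/C=C\c2cc3ccc(Cl)cc3nc2Cl)cc1`: 26400 nM

Compound 1 sits within the scatter of both other compounds, so the three measured values form a single band with no meaningful order among them.

The next compound is compound 4 `Fc1ccc(/C=C\c2cc3ccc(Cl)cc3nc2Cl)cc1`, still unmeasured. It follows from compound 1 by one change: chloro in place of hydrogen on an aromatic carbon. In words, chloro replaces hydrogen on an aromatic carbon of the core.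

Among the measured compounds shown here, only one measured step is available, a 1.1-fold higher number from compound 1 to compound 2 (0.03 log units; within the scatter). It reflects (the fact that compounds 1 and 2 differ only in the configuration as drawn), so it shows tolerance to that change alone. For the measured compounds named here, no measured step isolates the chloro. The remaining guide is the band itself, with compound 3 at 26400 nM and compound 1 at 35700 nM. On that basis, no step beyond the scatter is expected in this assay, with at most a slight lean towards a lower number.

The estimated step is a 1.2-fold lower number from compound 1 to compound 4 (0.09 log units; within the scatter).

For compound 4 the expected value is 29000 nM, with an estimated range from 14000 nM to 58000 nM.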

Compound 4, half-maximal inhibitory concentration: 26900 nM
Beside the measured number, compound 4's estimate is 1.1-fold (0.03 log units) above it; measured number inside the range.
By their numbers in this assay, from the lowest: compounds 3, 4, 1 and 2 (each within the scatter of the next).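

Compound 4 separates the two changes that compound 3 carries together relative to compound 1, showing that the chloro alone on this aromatic carbon, meta to a fused ring and para to a fused ring, stays within the scatter in this assay (a 1.3-fold lower number from compound 1 to compound 4 (0.12 log units; within the scatter)). With that chloro in place on the core, the group on the other aromatic ring can also be exchanged within the scatter in this assay (a 1.0-fold higher number from compound 3 to compound 4 (0.01 log units; within the scatter)), so neither the fluoro nor the trifluoromethyl separates these two compounds on this read-out. The only available structural fact concerns the drawn configuration of compounds 1 and 2 and offers no explanation for the chloro or for the exchange of fluoro and trifluoromethyl.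

All four compounds remain in one band, so nothing shown here identifies a change at this position that moves the number beyond the scatter. Open questions are whether an amine or a carboxylic acid on this aromatic carbon would stay within that band, and whether the tolerance to the double-bond configuration persists with chloro on the core.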